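A Second Chloro on the Core of Compound 1

This account rests on a few compounds, and the source may have more. Where it says the series, first, only, none or still open, it means among the compounds named here.

Compound 1 (`NS(=O)(=O)c1cc2cc(Cl)ccc2oc1=O`) gives 57800 nM in a functional assay on A-431 cells (Homo sapiens) for antiproliferative activity, read by MTT assay, with a stated time of 72 h (on this read-out higher numbers stand for weaker inhibition and lower numbers for stronger inhibition), and compound 2 (`NS(=O)(=O)c1cc2cc(Br)ccc2oc1=O`) gives 49200 nM there as well. Among the compounds with values here, these are the only two numbers so far, and they cannot be ranked. Within the data shown here, the one measured step, bromo in place of chloro on an aromatic carbon, is a 1.2-fold lower number from compound 1 to compound 2 (0.07 log units; within the scatter) in size.

Compound 3 (`NS(=O)(=O)c1cc2cc(Cl)cc(Cl)c2oc1=O`) keeps the core of compound 1 and carries one further chloro in place of hydrogen on an aromatic carbon. The new group sits ortho to a fused ring and meta to a chloro group. The measured step bears on this only loosely, since it swaps one halogen for another, whereas compound 3 gains a group where hydrogen stood. Among the measured compounds shown here, no measured step shows such a gain.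

With so little to go on, only a modest move is expected in this assay, most likely staying within the scatter. The expected step is a 1.4-fold lower number from compound 1 to compound 3 (0.14 log units; within the scatter) and no more than that. For compound 3 the estimated value is 42000 nM and the expected range runs from 17000 nM to 100000 nM in this read-out.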

Compound 3, half-maximal inhibitory concentration: 35200 nM
The estimate for compound 3 lay 1.2-fold (0.08 log units) above the measured number; measured number inside the range.
By their numbers in this assay, from the lowest: compounds 3, 2 and 1 (each within the scatter of the next).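

The first case here of a group entering where hydrogen stood, chloro in place of hydrogen on an aromatic carbon, ortho to a fused ring and meta to a chloro group, gives in this assay a step of a 1.6-fold lower number from compound 1 to compound 3 (0.22 log units; within the scatter). This shows that a second chloro can be carried at this position of the shared core without a step beyond the scatter, something the earlier pair could not show, as it only exchanged one halogen for another at a place already substituted. Nothing available bears on why the step has this size.

The compounds shown leave open whether this position can give a step beyond the scatter at all, as every step so far lies within it and every group tried on the core is a halogen. An amine, a methoxy group or a carboxylic acid at this position would show whether anything other than a halogen moves the number in this read-out, and a bromo there would show whether the two halogens again stay within the scatter of each other.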